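The source may report more compounds than this note shows. Statements on the series, on what has been measured and on what is new or still open speak of the compounds shown alone.

Measured so far in a functional assay on CCRF-CEM cells (Homo sapiens) for inhibition, read by MTT assay, with a stated time of 4 days; on this read-out higher numbers stand for weaker inhibition and lower numbers for stronger inhibition:
compound 1 `COc1cc(NC(C)CCCNC(=O)NNC(=O)NCCCCCO)c2ncccc2c1` gives 170000 nM
compound 2 `COc1cc(NC(C)CCCNC(=O)NNC(=O)NCCNC(c2ccccc2)(c2ccccc2)c2ccccc2)c2ncccc2c1` gives 4200 nM
compound 3 `CCOC(=O)N(C)C(c1ccccc1)c1ccccc1` gives 108000 nM

Compound 1 at 170000 nM and compound 3 at 108000 nM lie within the scatter of each other, so compound 1 shares the high end of the numbers with compound 3. Compound 2 at 4200 nM lies well under compound 1, a gap beyond the scatter.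

The next compound is compound 4 `COc1cc(NC(C)CCCNC(=O)NNC(=O)NC(CO)(CO)CO)c2ncccc2c1`, which keeps the core of compound 1. The change reads 2-hydroxy-1,1-bis(hydroxymethyl)ethyl in place of 5-hydroxypentyl on an amide-type nitrogen and puts 2-hydroxy-1,1-bis(hydroxymethyl)ethyl in place of 5-hydroxypentyl on an amide-type nitrogen. Among the measured compounds shown here, no measured pair isolates a change of this kind, so the size of the step is a matter of judgment. Neither the leaving group nor the entering group has a ring, and compound 1 at 170000 nM is the closest measured reference. For this assay no step beyond the scatter is therefore expected. The estimate means an expected step of a 1.1-fold lower number from compound 1 to compound 4 (0.05 log units; within the scatter) and no more. Compound 4 is estimated at 150000 nM with an expected range of 60000 nM to 400000 nM for repeated measurements.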

Compound 4, half-maximal inhibitory concentration: > 250000 nM
Compound 4: only a limit was reported (the forecaster's own chance of this, stated with the estimate: 20%); middle value at least 1.6-fold (0.22 log units) away from the limit.
By their numbers in this assay, from the lowest: compound 2; then compounds 3 and 1 (each within the scatter of the next). At a limit, above all of these: compound 4.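

Compound 4 gives > 250000 nM in this assay, and this value is a limit of the assay rather than a number. Placing 2-hydroxy-1,1-bis(hydroxymethyl)ethyl in place of 5-hydroxypentyl on the amide-type nitrogen gives an at least 1.4-fold higher number from compound 1 to compound 4 (0.16 log units; that floor lies within the scatter), so this first pair at the position shows no stronger inhibition with the change, although the floor of the step does not separate the two compounds. The result therefore fixes only the direction that can be excluded, a step to a clearly lower number, and leaves the true size of the step unread: the limit of > 250000 nM in this assay, at which 1 of the 4 values shown sits.

Among the compounds shown here, what remains open is whether any group on this amide-type nitrogen can lower the number in this assay while the rest of compound 1 stays unchanged, since the pair covers only two hydroxylated groups. A primary amine or a carboxylic acid at the end of the five-carbon chain of 5-hydroxypentyl, or a longer alkyl chain ending in hydroxyl, would test this position in a single change and would show how far the number can move from here.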